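The source may report more compounds than this note shows. Statements on the series, on what has been measured and on what is new or still open speak of the compounds shown alone.

Two members of the series have been measured in a functional assay on HeLa cells (Homo sapiens) for cytotoxicity, read by cell counting, with a stated time of 4 days; a higher number here means a weaker inhibitor, a lower number a stronger inhibitor. Compound 1 `C=C(Br)C(=O)Nc1cccc(/C=C2\SC(=O)N(Cc3ccc(C)cc3)C2=O)c1` gives 1200 nM in this assay. Compound 2 `C=C(Br)C(=O)Nc1ccc(/C=C2\SC(=O)N(Cc3ccc(C)cc3)C2=O)cc1` gives 8900 nM in this assay, the highest of the two numbers; its nearest neighbour on the scale is compound 1, whose number is lower by a gap that lies beyond the usual scatter. Compound 3 `C=C(Br)C(=O)Nc1ccc(/C=C2\SC(=O)N(Cc3ccc(F)cc3)C2=O)cc1` is not yet measured. It differs from compound 2 in one place: fluoro in place of methyl on an aromatic carbon. Going by the values given here, no pair of measured compounds differing in one place is available, so there is no measured step to lean on; the two values show only that compound 1 and compound 2 sit well apart. The exchange of methyl for fluoro is expected to move the number little, with no step beyond the scatter in either direction, so the expected step is a 1.1-fold lower number from compound 2 to compound 3 (0.05 log units; within the scatter). For compound 3 the estimate in this assay is 8000 nM, within 3000 nM to 22000 nM.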

Compound 3, half-maximal inhibitory concentration: 2000 nM
Compound 3: middle estimate off by 4.0-fold (0.60 log units), on the high side; the measured number lies below the stated range.
By their numbers in this assay, from the lowest: compounds 1 and 3 (each within the scatter of the next); then compound 2.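

The 4-methylbenzyl position now has its first measured step: in this assay, going to 4-fluorobenzyl gives a 4.5-fold lower number from compound 2 to compound 3 (0.65 log units; beyond the scatter) on the shared core. This exchange on an aromatic carbon, para to a large group, is therefore not silent in this series, even though methyl and fluoro each count as one heavy atom, with no hydrogen-bond donors or acceptors. Nothing at hand explains the size or direction of this step, so it remains an observation on one pair.

On these data alone, it remains open whether fluoro in place of methyl moves the number in the same direction on the core of compound 1. Also open, as far as these compounds go, is where a chloro, methoxy or trifluoromethyl group on this same carbon would place the number relative to compound 2 and compound 3.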